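This account rests on a few compounds, and the source may have more. Where it says the series, first, only, none or still open, it means among the compounds named here.

Within the data shown here, compound 2 `CN(C)c1ccc(C(=O)N(CCC(=O)NCc2ccccc2)Cc2ccc(C(=O)NO)cc2)cc1` gives 14.8 nM in an assay on Sf9 cells for inhibition of protein deacetylase HDAC6 (Homo sapiens), read by fluorescence, with stated times of 90 min and 30 min (on this read-out lower numbers stand for stronger inhibition and higher numbers for weaker inhibition), the lower of the two numbers so far, though compound 1 `Cc1ccc(NC(=O)CCN(Cc2ccc(C(=O)NO)cc2)C(=O)c2ccc(N(C)C)cc2)cc1`, at 19.5 nM, lies within the scatter of it. Among the measured compounds shown here, the only measured step, a 1.3-fold lower number from compound 1 to compound 2 (0.12 log units; within the scatter), exchanges the whole group on the amide-type nitrogen and stays within the scatter. Compound 3 `Cc1ccc(CNC(=O)CCN(Cc2ccc(C(=O)NO)cc2)C(=O)c2ccc(N(C)C)cc2)cc1` differs from compound 2 by methyl in place of hydrogen on an aromatic carbon, a smaller change at the same end of the molecule. For the measured compounds named here, no measured step matches it exactly; the single step that touches this part of the structure was small, and the measured numbers give no reason to expect the methyl to move the read-out. The expected step is therefore a 1.0-fold higher number from compound 2 to compound 3 (0.01 log units; within the scatter), nothing beyond the scatter. Compound 3 is accordingly estimated at 15 nM in this assay, with a range from 7 nM to 32 nM, pending measurement.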

Compound 3, half-maximal inhibitory concentration: 14.4 nM
Compound 3: middle estimate off by 1.0-fold (0.02 log units), on the high side; the measured number falls inside the stated range.
By their numbers in this assay, from the lowest: compounds 3, 2 and 1 (each within the scatter of the next).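

Methyl in place of hydrogen on an aromatic carbon, para to a large group, gives a 1.0-fold lower number from compound 2 to compound 3 (0.01 log units; within the scatter) in this assay and so adds a change on the ring itself to the earlier exchange of the whole group. With the methyl present in both compounds, 4-methylbenzyl in place of 4-methylphenyl gives a 1.4-fold lower number from compound 1 to compound 3 (0.13 log units; within the scatter) and likewise stays within the scatter, so neither change separates these three compounds. Nothing available explains why the read-out stays this flat.

As far as these compounds go, whether a larger or different group on this ring carbon, such as methoxy, a chlorine atom or an amine, would move the number beyond the scatter remains open. The same holds for a longer chain in place of benzyl on the amide-type nitrogen.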